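Removing the Aryl Ketone from a Sulfur-Linked Chain

The compounds below may be only part of what the source reports. "The series", "measured", "known", "first", "only" and "open" are said of these compounds alone.

Compound 1 `CCc1nnc(SCc2ccccc2)n1N1C(=O)c2ccccc2C1=O` is tested in a functional assay on PC-3M cells (Homo sapiens) for cytotoxicity, read by MTT assay, with a stated time of 48 h; a higher number here means a weaker inhibitor, a lower number a stronger inhibitor; there compound 1 reaches only the limit > 200000 nM, not a number. Compound 2 `CCc1nnc(SCC(=O)c2ccc(Cl)cc2)n1N1C(=O)c2ccccc2C1=O` carries a (4-chlorophenyl)carbonyl in place of phenyl on a saturated chain carbon bound to a sulfur, and in this assay compound 2 likewise stops at the limit > 200000 nM. The step that the two limits leave unreadable from compound 1 to compound 2 therefore cannot be read, since (the limit of > 200000 nM in this assay, at which 2 of the 2 values shown sit). Compound 3 `CCc1nnc(SC)n1N1C(=O)c2ccccc2C1=O` differs from compound 2 by hydrogen in place of (4-chlorophenyl)carbonyl on a saturated chain carbon bound to a sulfur. With no readable step to guide it, compound 3 is expected to remain at the limit as well, so the estimated step that the limit leaves unreadable from compound 2 to compound 3 is small. Compound 3 is estimated at 300000 nM, within 100000 nM to 1000000 nM.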

Compound 3, half-maximal inhibitory concentration: > 200000 nM
Compound 3 was reported as a limit; the forecaster's own chance of this, stated with the estimate: 85%; the middle value does not contradict the limit.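

Compound 3 gives only a limit, as do compound 1 and compound 2, so no step among them can be read: the limit of > 200000 nM in this assay, at which 3 of the 3 values shown sit.

The compounds shown leave open whether phenyl, (4-chlorophenyl)carbonyl or hydrogen on a saturated chain carbon bound to a sulfur makes any difference in this assay.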